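A few compounds are considered here, and "the series" means these few. Any claim that something is new, unique, unknown or untested is made for them only; others in the source may bear on it.

The series centers on a shared core, and compound 1 `CC(C(=O)NCc1ccc(C(F)(F)F)nc1NCc1cccnc1)c1ccc(NS(C)(=O)=O)c(F)c1` is its simplest member. In a functional assay on CHO-K1 cells for antagonist activity at transient receptor potential cation channel subfamily V member 1 (Homo sapiens), read by FLIPR (on this read-out higher numbers stand for weaker inhibition and lower numbers for stronger inhibition), compound 1 is reported only as "not active" (no number reported), so no single number describes where it stands; it can only be placed beside the compounds that did give a value. Compound 2 `C[C@H](C(=O)NCc1ccc(C(F)(F)F)nc1N1CC[C@@H](OCc2ccccc2)C1)c1ccc(NS(C)(=O)=O)c(F)c1` carries a different substituent on the aromatic carbon next to the ring nitrogen, and in this assay compound 2 gives 50 nM. Compound 3 `C[C@@H](C(=O)NCc1ccc(C(F)(F)F)nc1N1CCC(c2ccccc2)CC1)c1ccc(NS(C)(=O)=O)c(F)c1` is built the same way with another group at that carbon, and in this assay compound 3 gives 2350 nM. Those two values lie far apart, so the group on that carbon clearly matters.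

Compound 4 `CCCCOC1CCN(c2nc(C(F)(F)F)ccc2CNC(=O)C(C)c2ccc(NS(C)(=O)=O)c(F)c2)CC1` differs from compound 1 in exactly that position: a group of 11 heavy atoms (9 carbon, 1 nitrogen, 1 oxygen; one six-membered non-aromatic ring with 1 hetero atom) in place of a group of 8 heavy atoms (6 carbon, 2 nitrogen; one six-membered aromatic ring with 1 hetero atom), on an aromatic carbon. Among the measured compounds shown here, no measured pair mirrors this step, so its size cannot be read from the data; since compound 1 has no number, only a direction can be offered, and because compound 2 reaches 50 nM with a saturated ring on the same carbon, a gain toward activity is expected. Compound 4 is estimated to give about 400 nM in this assay, within a range from 80 nM to 3000 nM.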

Compound 4, half-maximal inhibitory concentration: 28.2 nM
Estimate against measurement, compound 4: 14-fold (1.15 log units) above; measured number outside the range, below it.
By their numbers in this assay, from the lowest: compounds 4 and 2 (each within the scatter of the next); then compound 3.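

Compound 1 has no number in this assay, so the change from compound 1 to compound 4 cannot be read as a step. The compounds shown leave open which feature of the group on that aromatic carbon separates compound 4 from compound 1. Nothing shown here offers an explanation for the result.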